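Formyl, hydroxymethyl and an ethoxycarbonyl still to measure

A few compounds are considered here, and "the series" means these few. Any claim that something is new, unique, unknown or untested is made for them only; others in the source may bear on it.

Measured in a functional assay on NALM-6 cells (Homo sapiens) for cytotoxicity, with a stated time of 72 h; a lower number here means that less compound is needed, a higher number that more compound is needed for the effect:
compound 1 `C=C[C@@](C)(/C=C/c1ccc(O)cc1)CC/C=C(C)/C=N/N` gives > 43400 nM ( a limit )
compound 2 `C=C[C@@](C)(/C=C/c1ccc(O)cc1)CC/C=C(\C)C=O` gives 12600 nM
compound 3 `C=C[C@@](C)(/C=C/c1ccc(O)cc1)CC/C=C(\C)CO` gives > 43400 nM ( a limit )

Compound 3 stands at the limit of > 43400 nM in this assay, at which 2 of the 3 values shown sit, and gives no number. Compound 4 `C=C[C@@](C)(/C=C/c1ccc(O)cc1)CC/C=C(\C)C(=O)OCC` differs from compound 3 by ethoxycarbonyl in place of hydroxymethyl on a double-bonded chain carbon bound to a double-bonded chain carbon and a saturated chain carbon on a double-bonded chain carbon bound to a double-bonded chain carbon and a saturated chain carbon.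

Within the data shown here, two measured steps bear on this carbon. Hydroxymethyl in place of formyl gave an at least 3.4-fold higher number from compound 2 to compound 3 (0.53 log units; beyond the scatter) and this is the closest comparison. Formyl entering at the same carbon in the other readable change gave an at least 3.4-fold lower number from compound 1 to compound 2 (0.53 log units; beyond the scatter) as well. Both sizes are minimum sizes, and neither step involves ethoxycarbonyl.

Ethoxycarbonyl holds a carbonyl, as the formyl of compound 2 does (12600 nM), so a modest move to a lower number is expected. For compound 4 a limit is still possible. The expected change is an at least 1.7-fold lower number from compound 3 to compound 4 (0.23 log units; that floor lies within the scatter) in this assay as an estimate only. The estimated value for compound 4 is 25000 nM within an expected range of 9000 nM to 60000 nM in the same read-out.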

Compound 4, half-maximal effective concentration: > 43400 nM
Compound 4: a limit, no number; the forecaster's own chance of this, stated with the estimate: 40%; at least 1.7-fold (0.23 log units) between middle value and limit.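

At this double-bonded chain carbon in this assay, keeping the carbonyl does not keep the measurable effect: ethoxy in place of hydrogen on the carbonyl carbon gave an at least 3.4-fold higher number from compound 2 to compound 4 (0.53 log units; beyond the scatter). Of the four compounds, only compound 2, with formyl, gives a number at this position, so the carbonyl that compound 4 shares with it is not sufficient on its own, and the earlier link between a carbonyl and a lower number now holds for formyl alone. The steps from compound 1 and from compound 3 to compound 4 cannot be read, because compound 1, compound 3 and compound 4 each give only a limit, the same one at both ends of each step: the limit of > 43400 nM in this assay, at which 3 of the 4 values shown sit.

On these data alone, how compound 1, compound 3 and compound 4 rank among themselves stays open, and so does whether any group at this carbon can go lower than compound 2, which gives 12600 nM. A carboxylic acid or a primary amide at the same carbon would show whether the loss seen with ethoxycarbonyl follows the ethoxy part or extends to other carbonyl groups.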